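Propyl to pentyl from compound 2 to compound 3

This account rests on a few compounds, and the source may have more. Where it says the series, first, only, none or still open, it means among the compounds named here.

Measured so far in a physicochemical assay for lipophilicity; a higher number here means a more lipophilic compound, a lower number a more polar compound:
- compound 1 `CCCCCCNC(=O)c1ccc(S(N)(=O)=O)cc1` gives 2.05 as its value
- compound 2 `CCCOC(=O)c1ccccc1S(N)(=O)=O` gives 1.49 as its value

Compound 2 stands lowest of these two, and the gap up to compound 1 lies beyond the scatter. Within the data shown here, the two measured compounds differ in more than one place, so no measured step is available to read across. The expectation therefore rests on the structural change alone.

Compound 3 `CCCCCOC(=O)c1ccccc1S(N)(=O)=O` differs from compound 2 by ethyl in place of hydrogen on a saturated chain carbon, three bonds along the chain from an oxygen next to a carbonyl group, a difference that also reads as propyl to pentyl. A rise in this assay beyond the scatter is expected, and the estimated size is a number 1.01 log units higher from compound 2 to compound 3 (beyond the scatter) for this change. For compound 3 the estimate is 2.5, with an expected range from 2.2 to 2.85 once it is measured.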

Compound 3, partition coefficient: 2.55
For compound 3 the middle estimate is 0.05 log units below the measured one; the range from low to high includes it.
By their numbers in this assay, from the lowest: compound 2; then compound 1; then compound 3.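

Propyl to pentyl at this place gives a number 1.06 log units higher from compound 2 to compound 3 (beyond the scatter) in this assay and is the first step in the series that can be read at a single place. The step is large, so the read-out responds strongly to ethyl in place of hydrogen on a saturated chain carbon, three bonds along the chain from an oxygen next to a carbonyl group. No measurement shown here accounts for the size of this step.

On these data alone, whether the rise continues with a longer chain, or whether an amine or a carboxylic acid at the end of the chain would reverse it, remains open. As far as these compounds go, with one step at one position, it is also open whether the same change would move the chain of compound 1 to a similar extent.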